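A few compounds are considered here, and "the series" means these few. Any claim that something is new, unique, unknown or untested is made for them only; others in the source may bear on it.

In a functional assay on A549 cells (Homo sapiens) for inhibition, read by sulforhodamine B assay, with a stated time of 48 h, tested at 50 uM (a lower number here means less inhibition of growth, a higher number more inhibition of growth at the concentration tested), compound 1 (`CCCOc1ccc([C@@H]2CC(=O)c3cc(CC=C(C)C)c(OC)cc3O2)cc1`) gives 43%. Two other measured compounds offer context. Compound 3 (`COc1cc2c(cc1CC=C(C)C)[C@H](O)C[C@@H](c1ccc(O)cc1)O2`) gives 48%, and compound 2 (`COc1ccc([C@@H]2C/C(=N/OCc3cn(-c4ccc(C(=O)c5ccccc5)cc4)nn3)c3cc(CC=C(C)C)c(OC)cc3O2)cc1`) gives 34%. Each of these two values lies within the usual scatter of the value for compound 1, so neither gap can be read as a real difference.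

Compound 4 (`C#CCOc1ccc([C@@H]2CC(=O)c3cc(CC=C(C)C)c(OC)cc3O2)cc1`) keeps the core of compound 1 and changes one place, on a saturated chain carbon bound to an oxygen on an aromatic ring: ethynyl in place of ethyl on a saturated chain carbon bound to an oxygen on an aromatic ring. Seen one bond further out, propoxy becomes propargyloxy.

Among the compounds with values here, no two measured compounds differ in just one place, so the data hold no direct precedent for this change. Within the data shown here, the only guide is indirect. Compound 1 and compound 2 differ in a far larger way, yet their values stay within the scatter of each other, with compound 2 at 34%. A small swap at the end of a chain is therefore not expected to produce a step beyond the scatter in this assay, in either direction. The expected step is a number 1 percentage points lower from compound 1 to compound 4 (within the scatter). For compound 4, the estimated value is 42%, with an expected range from 30% to 55%.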

Compound 4, percent growth inhibition at one concentration: 53%
Compound 4: the middle estimate sits 11 percentage points below what was measured; the measured number falls inside the stated range.
By their numbers in this assay, from the lowest: compounds 2, 1, 3 and 4 (each within the scatter of the next, the first and the last beyond it).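

Within the data shown here, this is the first change in the set made in a single place, and swapping propoxy for propargyloxy gives a number 10 percentage points higher from compound 1 to compound 4 (within the scatter) in this assay. On this evidence, compound 1 and compound 4 cannot be told apart, so ethyl can give way to ethynyl on a saturated chain carbon bound to an oxygen on an aromatic ring, adding a triple bond outside the aromatic rings, with no real difference in growth inhibition at the concentration tested. No supporting evidence is available to explain how this change relates to the result.

The compounds shown leave open whether this place would accept a larger change, such as a longer chain or an ethyl replaced by an amine or a carboxylic acid, without a step beyond the scatter in this assay. They also leave open whether compound 1 and compound 4 would stay indistinguishable at other concentrations, since a reading at one concentration gives no view of how growth inhibition changes with dose.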